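Nitroimidazole amides: trifluoromethoxy for fluoro, cell toxicity

The source may hold more compounds than are shown below. What is called first, only, known or untested is meant among the compounds shown, and "the series" means these compounds.

Measured so far:
compound 1 `Cn1c([N+](=O)[O-])cnc1C(=O)NCc1ccc(F)cc1` — > 100000 nM
compound 2 `O=C(NCc1ccc(F)cc1)c1ncc([N+](=O)[O-])[nH]1` — > 100000 nM

In a toxicity assay on HEK293 cells (Homo sapiens) for inhibition, read by resazurin assay, with a stated time of 24 h (on this read-out lower numbers stand for higher toxicity in this test and higher numbers for lower toxicity in this test), compound 1 gives > 100000 nM, which is a limit of the assay rather than a number. In this assay compound 2 gives > 100000 nM, also a limit and not a number. For the measured compounds named here, the one step, a step that the two limits leave unreadable from compound 1 to compound 2, cannot be read because of the limit of > 100000 nM in this assay, at which 2 of the 2 values shown sit. Compound 2 therefore stands only at the limit on the numbers shown, with no measured number beside it; the further value shown, that of compound 1, is a limit as well.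

Compound 3 `O=C(NCc1ccc(OC(F)(F)F)cc1)c1ncc([N+](=O)[O-])[nH]1` is to be measured in this assay. Its change from compound 2 is trifluoromethoxy in place of fluoro on an aromatic carbon. Going by the values given here, no measured step involves a change of this kind, and the only step available is unreadable, so nothing in the numbers speaks for a step in either direction. The working expectation is that compound 3 again comes out at or beyond the limit of this assay, with an estimate of 100000 nM and a range from 30000 nM to 300000 nM. The step of a number no higher from compound 2 to compound 3 (the limit leaves the size open) is accordingly expected to be none beyond the scatter.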

Compound 3, half-maximal cytotoxic concentration: > 100000 nM
Compound 3 ended at the assay's limit; the forecaster's own chance of this, stated with the estimate: 70%; the middle value lies on the limit itself.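

No size can be read for the change from compound 2 to compound 3, or for any other step in the series, because all three compounds sit at the same limit: the limit of > 100000 nM in this assay, at which 3 of the 3 values shown sit.

The compounds shown leave open how far trifluoromethoxy in place of fluoro shifts the half-maximal cytotoxic concentration in this assay, and in which direction.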